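One Fluoro Group Fewer on Compound 3

This account rests on a few compounds, and the source may have more. Where it says the series, first, only, none or still open, it means among the compounds named here.

Of the compounds shown here, three sharing a core have been measured in an ADME assay on HepG2 cells (Homo sapiens) for cytotoxicity, with a stated time of 72 h; a higher number here means that more compound is needed for the effect, a lower number that less compound is needed. Compound 3 (`Cc1cc(NC(=O)Nc2ccc(F)c(F)c2)c2ccccc2n1`) gives 21000 nM. Compound 1 (`CSc1ccc(NC(=O)Nc2cc(C)nc3ccccc23)cc1`) gives 16000 nM, and this lies within the usual scatter of the value of compound 3, so the two cannot be told apart. For compound 2 (`Cc1cc(NC(=O)Nc2ccccc2N)c2ccccc2n1`) the result in this assay is a limit, > 25000 nM, and not a number.

Compound 4 (`Cc1cc(NC(=O)Nc2ccc(F)cc2)c2ccccc2n1`) has not yet been measured and differs from compound 3 in one place: hydrogen in place of fluoro on an aromatic carbon. Hydrogen takes the place of fluoro on an aromatic carbon, ortho to a fluoro group and meta to a large group.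

For the measured compounds named here, no two measured compounds differ in only one place, so no measured step gauges this exchange directly. The expectation rests on compound 3 at 21000 nM and compound 1 at 16000 nM, which stay within the scatter of each other although their structures differ. In this assay, no step beyond the scatter is therefore expected. As a number, the expected change is a 1.1-fold lower number from compound 3 to compound 4 (0.02 log units; within the scatter). Compound 4 is estimated at 20000 nM, with an expected range from 11000 nM to 36000 nM.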

Compound 4, half-maximal effective concentration: > 25000 nM
Compound 4: only a limit was reported; the forecaster's own chance of this, stated with the estimate: 30%; middle value at least 1.2-fold (0.09 log units) from the limit.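

In this assay, for the compounds shown here, the exchange of fluoro for hydrogen on this aromatic carbon, ortho to a fluoro group and meta to a large group, can now be read directly for the first time: an at least 1.1-fold higher number from compound 3 to compound 4 (0.07 log units; that floor lies within the scatter). That step is only a floor, and it does not show that losing this fluoro group moves the result beyond the scatter, nor does it fix the true size of the change. Fluoro in place of methylsulfanyl on an aromatic carbon is also a floor within the scatter, an at least 1.5-fold higher number from compound 1 to compound 4 (0.19 log units; that floor lies within the scatter), whereas the step between compound 2 and compound 4 cannot be read because both results are limits: the limit of > 25000 nM in this assay, at which 2 of the 4 values shown sit.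

On these data alone, the true size of the step from compound 3 to compound 4 stays open, since the result for compound 4 is a limit and not a number. The compounds shown also leave open whether a chloro or a methoxy group on this aromatic carbon would give a number or another limit in this assay.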